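The source may hold more compounds than are shown below. What is called first, only, known or untested is meant among the compounds shown, and "the series" means these compounds.

Measured compounds in a functional assay on SGC-7901 cells (Homo sapiens) for cytotoxicity, read by MTT assay, with a stated time of 48 h; a higher number here means a weaker inhibitor, a lower number a stronger inhibitor:
compound 1 `O=c1ccoc2cc(OCc3cn(Cc4ccc([N+](=O)[O-])cc4)nn3)ccc12`; the value of compound 1 is a limit of the assay, > 100000 nM.
compound 2 `O=c1ccoc2cc(OCc3cn(Cc4cccc(Br)c4)nn3)ccc12`; the value of compound 2 is a limit of the assay, > 100000 nM.
compound 3 `O=c1ccoc2cc(OCc3cn(Cc4ccc(Cl)cc4)nn3)ccc12`; the value of compound 3 is a limit of the assay, > 100000 nM.

All three share one core and differ only in the aryl group on the saturated chain carbon bound to an aromatic nitrogen. Compound 3 stands at the limit, and nothing in this assay sets it apart from the other two. The steps a step that the two limits leave unreadable from compound 1 to compound 2, a step that the two limits leave unreadable from compound 1 to compound 3 and a step that the two limits leave unreadable from compound 2 to compound 3 are all unreadable, since every value sits at the same boundary: the limit of > 100000 nM in this assay, at which 3 of the 3 values shown sit.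

The next compound, compound 4 `O=c1ccoc2cc(OCc3cn(Cc4cccc([N+](=O)[O-])c4)nn3)ccc12`, carries the change (3-nitrophenyl in place of 4-chlorophenyl on a saturated chain carbon bound to an aromatic nitrogen). Going by the values given here, a nitrophenyl group already occurs in compound 1, whose value is a limit, so no measured step gives a readable size for this kind of exchange. With every aryl variant so far inactive up to the limit, compound 4 is expected to behave the same way in this assay. The step of a number no higher from compound 3 to compound 4 (the limit leaves the size open) is expected to be none beyond the scatter. The estimate for compound 4 is 100000 nM, with a range from 30000 nM to 300000 nM, most likely reported again as a limit.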

Compound 4, half-maximal inhibitory concentration: > 100000 nM
Compound 4: only a limit was reported (the forecaster's own chance of this, stated with the estimate: 85%); the middle value lies on the limit itself.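

In this assay compound 4 gives > 100000 nM as a limit of the assay. Going by these compounds alone, no step among compound 1, compound 2, compound 3 and compound 4 can be read, since all four values sit at one boundary: the limit of > 100000 nM in this assay, at which 4 of the 4 values shown sit. The compounds shown leave open how these aryl variants on the shared core rank against one another, and at what concentration, if any, each reaches half-maximal inhibition.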